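The source may hold more compounds than are shown below. What is called first, only, known or untested is meant among the compounds shown, and "the series" means these compounds.

Compound 3 `COc1ccc(CNC(=O)/C(C#N)=C/c2ccc(Br)o2)cc1` gives 9000 nM in a functional assay on A-431 cells (Homo sapiens) for inhibition, read by MTT assay, with a stated time of 72 h; on this read-out higher numbers stand for weaker inhibition of growth and lower numbers for stronger inhibition of growth. Compound 2 `COc1ccc(CNC(=O)/C(C#N)=C/c2ccc(Cl)o2)cc1` gives 9000 nM in this assay, and no change at the digits printed from compound 2 to compound 3 (within the scatter). Compound 1 `COc1ccc(CNC(=O)/C(C#N)=C/c2ccc[nH]2)cc1` gives > 50000 nM in this assay, which is a limit of the assay and not a number. Compound 4 `COc1ccc(CNC(=O)/C(C#N)=C/c2ccc(C)cc2)cc1` carries 4-methylphenyl in place of 5-bromofuran-2-yl on a double-bonded chain carbon bound to a double-bonded chain carbon. The measured steps that bear on this change are an at least 5.5-fold lower number from compound 1 to compound 2 (0.74 log units; beyond the scatter) and an at least 5.5-fold lower number from compound 1 to compound 3 (0.74 log units; beyond the scatter), so swapping the aromatic ring on a double-bonded chain carbon bound to a double-bonded chain carbon has already moved growth inhibition by at least a modest amount. For the measured compounds named here, no measured step exchanges a halofuran for a phenyl ring, so the direction of this one is open. Compound 4 is therefore expected to give about 20000 nM, between 5000 nM and 80000 nM, a step of a 2.2-fold higher number from compound 3 to compound 4 (0.35 log units; beyond the scatter) that is only an estimate.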

Compound 4, concentration for 50% growth inhibition: 26000 nM
Beside the measured number, compound 4's estimate is 1.3-fold (0.11 log units) below it; measured number inside the range.
By their numbers in this assay, from the lowest: compounds 2 and 3 (each within the scatter of the next); then compound 4. At a limit, above all of these: compound 1.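

4-methylphenyl in place of 5-bromofuran-2-yl on a double-bonded chain carbon bound to a double-bonded chain carbon gives a 2.9-fold higher number from compound 3 to compound 4 (0.46 log units; beyond the scatter) and 4-methylphenyl in place of 5-chlorofuran-2-yl gives a 2.9-fold higher number from compound 2 to compound 4 (0.46 log units; beyond the scatter) so growth inhibition weakens in both comparisons. The same loss is seen against both halofurans. Compound 1 stands at a limit of the assay, which is not a number: the limit of > 50000 nM in this assay, at which 1 of the 4 values shown sits.

The step of an at least 1.9-fold lower number from compound 1 to compound 4 (0.28 log units; that floor lies within the scatter) is only a floor that lies within the scatter, so it does not show how far the two compounds differ.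

4-methylphenyl changes ring size, ring oxygen and halogen together, and the compounds shown do not separate these. An unsubstituted phenyl or a 5-methylfuran-2-yl group would help tell them apart.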